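A few compounds are considered here, and "the series" means these few. Any claim that something is new, unique, unknown or untested is made for them only; others in the source may bear on it.

Compound 2 `COc1cc2c(CN(C)C)coc2cc1C` was tested in a functional assay on HEK293 cells for agonist activity at melatonin receptor type 1A (Homo sapiens), read by calcium flux (on this read-out higher numbers stand for an effect only at larger amounts of compound and lower numbers for an effect already at smaller amounts), and gives 440000 nM. Compound 1 `COc1cc2c(CO)coc2cc1C` gives 700000 nM in this assay. These two numbers lie within the scatter of each other, so the data place compound 2 alongside compound 1 rather than apart from it. Compound 3 `CCN(CC)Cc1coc2cc(C)c(OC)cc12` has not yet been measured. It differs from compound 2 in one place: diethylamino in place of dimethylamino on a saturated chain carbon bound to an aromatic carbon. For the measured compounds named here, the only measured step at this same position, a 1.6-fold lower number from compound 1 to compound 2 (0.20 log units; within the scatter), did not reach beyond the scatter. Going by the values given here, that step exchanged a quite different group, and no measured pair shows the exchange of dimethylamino for diethylamino itself, so the hint it gives is loose. The expected step is a 1.1-fold lower number from compound 2 to compound 3 (0.04 log units; within the scatter), meaning no shift beyond the scatter in either direction. Compound 3 is therefore estimated to give 400000 nM in this assay, with a range from 150000 nM to 1200000 nM.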

Compound 3, half-maximal effective concentration: 360000 nM
Beside the measured number, compound 3's estimate is 1.1-fold (0.05 log units) above it; the range from low to high includes it.
By their numbers in this assay, from the lowest: compounds 3, 2 and 1 (each within the scatter of the next).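

In this assay, for the compounds shown here, the exchange of dimethylamino for diethylamino on a saturated chain carbon bound to an aromatic carbon gives a 1.2-fold lower number from compound 2 to compound 3 (0.09 log units; within the scatter) and so stays within the scatter, which is the first direct look at one amine exchanged for another at this position. The exchange of hydroxy for diethylamino gives a 1.9-fold lower number from compound 1 to compound 3 (0.29 log units; within the scatter) and also stays within the scatter, so hydroxy, dimethylamino and diethylamino cannot be told apart here. No measurement on hand explains why these exchanges leave the number within the scatter.

From the compounds shown here alone, whether a ring amine such as piperidine or morpholine, or a carboxylic acid, at this position would move the number beyond the scatter remains open. Going by these compounds, the methoxy and methyl groups stay the same throughout, so the effect of exchanging them also remains open.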